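The compounds below may be only part of what the source reports. "The series", "measured", "known", "first", "only" and "open" are said of these compounds alone.

Compound 3 (`O=C(Nc1cccc(F)c1)c1cc(=O)[nH]c2cc(-c3ccccc3)ccc12`) gives > 20000 nM in a functional assay on KYSE-70 cells for antiproliferative activity against KYSE-70 cell line (Homo sapiens), read by MTT assay, with a stated time of 72 h (on this read-out lower numbers stand for stronger inhibition and higher numbers for weaker inhibition), which is a limit and not a number. Compound 1 (`COc1ccc(NC(=O)c2cc(=O)[nH]c3cc(Br)ccc23)cc1`) gives > 20000 nM, also a limit. Compound 2 (`O=C(Nc1ccc(F)cc1)c1cc(=O)[nH]c2cc(Br)ccc12`) gives > 20000 nM, again a limit. Compound 4 (`O=C(Nc1cccc(F)c1)c1cc(=O)[nH]c2cc(-c3ccsc3)ccc12`) is compound 3 with thiophen-3-yl in place of phenyl on an aromatic carbon. Going by the values given here, the only measured step, a step that the two limits leave unreadable from compound 1 to compound 2, concerns a different change and offers no size to carry over. Since compound 3 sits with the others at the limit of > 20000 nM in this assay, at which 3 of the 3 values shown sit, no step beyond the scatter is expected in this assay, and no direction can be foreseen. The expected change is a step that the limit leaves unreadable from compound 3 to compound 4. Compound 4 is estimated at 25000 nM, with an expected range from 10000 nM to 60000 nM.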

Compound 4, half-maximal inhibitory concentration: 5100 nM
Beside the measured number, compound 4's estimate is 4.9-fold (0.69 log units) above it; the measured number lies below the stated range.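

Placing thiophen-3-yl in place of phenyl on this aromatic carbon gives, in this assay, an at least 3.9-fold lower number from compound 3 to compound 4 (0.59 log units; beyond the scatter). The earlier compounds shown here gave no readable step, whereas this one shows that the group at this position can change the read-out. Compound 4 is the only compound shown with a number rather than a limit: the limit of > 20000 nM in this assay, at which 3 of the 4 values shown sit.

Whether the sulfur atom or the five-membered ring accounts for the step remains open. A furan-3-yl or pyridin-3-yl group at this position could separate the two.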